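This account rests on a few compounds, and the source may have more. Where it says the series, first, only, none or still open, it means among the compounds named here.

Working notes on the series. Compound 1 is `CCOC(=O)c1c(-c2cccc(OC(C)C)c2)[nH]c2cc(OC)ccc2c1=O`, compound 2 is `CCCCOc1cccc(-c2[nH]c3cc(OC)ccc3c(=O)c2C(=O)OCC)c1`, compound 3 is `CCOC(=O)c1c(-c2cccc(Cl)c2)[nH]c2cc(OC)ccc2c1=O`, and the still unmeasured compound 4 is `CCOC(=O)c1c(-c2cccc([N+](=O)[O-])c2)[nH]c2cc(OC)ccc2c1=O`. In an ADME assay on Raji cells (Homo sapiens) for cytotoxicity, read by luminescence, with a stated time of 72 h (a higher number here means that more compound is needed for the effect, a lower number that less compound is needed), compound 1 gives only a limit of the assay, > 21500 nM. In this assay compound 2 likewise gives only a limit, > 21500 nM. In this assay compound 3 also gives only a limit, > 21500 nM. Compound 2 therefore stands at the limit of > 21500 nM in this assay, at which 3 of the 3 values shown sit, and has no number of its own within the series. All three measured steps are unreadable for the same reason: a step that the two limits leave unreadable from compound 1 to compound 2, a step that the two limits leave unreadable from compound 1 to compound 3 and a step that the two limits leave unreadable from compound 2 to compound 3 each run between two limits and show no size and no direction. The change to compound 4 is nitro in place of butoxy on an aromatic carbon. Of the measured steps, a step that the two limits leave unreadable from compound 2 to compound 3 is the closest in kind, being another replacement of butoxy on an aromatic carbon, but it gives no size to carry over. With no resolved number anywhere in this assay, no direction is readable for the step to compound 4, and the expectation can only be that it remains at the limit. The estimate for compound 4 is 30000 nM, expected to lie between 10000 nM and 100000 nM, which means an expected step that the limit leaves unreadable from compound 2 to compound 4.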

Compound 4, half-maximal effective concentration: > 21500 nM
Compound 4: a limit, no number (the forecaster's own chance of this, stated with the estimate: 80%); the middle value is on the limit's open side.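

Compound 4 gives only a limit in this assay, > 21500 nM, so its steps from compound 1, compound 2 and compound 3 cannot be read, and the series stays here: the limit of > 21500 nM in this assay, at which 4 of the 4 values shown sit.

The compounds shown leave open whether isopropoxy, butoxy, chloro and nitro differ at all in this assay, and in which direction.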